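The source may hold more compounds than are shown below. What is called first, only, known or untested is meant among the compounds shown, and "the series" means these compounds.

In a functional assay on MCF7 cells (Homo sapiens) for inhibition, read by sulforhodamine B assay (on this read-out higher numbers stand for weaker inhibition and lower numbers for stronger inhibition), three compounds sharing one core have been read. Compound 1 `CCCc1ccc(NC2=CC(=O)c3nc4n(c3C2=O)[C@H]2OC[C@@H](O)[C@H]2OC4)cc1` gives a number, 4660 nM. Compound 2 `O=C1C(Nc2ccccc2F)=CC(=O)c2c1nc1n2[C@H]2OC[C@@H](O)[C@H]2OC1` has no exact number, only a limit of > 4000 nM. Compound 3 `O=C1C=C(N2CCC2)C(=O)c2c1nc1n2[C@H]2OC[C@@H](O)[C@H]2OC1` also gives only a limit, > 16000 nM. Compound 4 `O=C1C(Nc2ccc(Br)cc2)=CC(=O)c2c1nc1n2[C@H]2OC[C@@H](O)[C@H]2OC1` has 4-bromophenyl in place of 2-fluorophenyl on an amine nitrogen. Among the compounds with values here, no measured pair shows this change, so no step beyond the scatter is expected in this assay. Within the data shown here, the only exact number as a guide is that of compound 1, at 4660 nM. The estimated change is a step that the limit leaves unreadable from compound 2 to compound 4. Compound 4 is estimated at 4500 nM, with an expected range of 1200 nM to 15000 nM.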

Compound 4, half-maximal inhibitory concentration: 4330 nM
For compound 4 the middle estimate is 1.0-fold (0.02 log units) above the measured one; the range from low to high includes it.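

No step can be read from compound 2 to compound 4, because compound 2 carries only a limit: the limit of > 4000 nM in this assay, at which 1 of the 4 values shown sits.

The compounds shown leave open whether 4-bromophenyl in place of 2-fluorophenyl on an amine nitrogen changes the read-out in this assay at all.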